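Isomeric bicyclic amide variant of compound 1 in HepG2 cytotoxicity

The compounds below may be only part of what the source reports. "The series", "measured", "known", "first", "only" and "open" are said of these compounds alone.

Measured compounds:
compound 1 `Nc1ccccc1NC(=O)c1ccc(CNC(=O)c2cc3cccnc3[nH]2)cc1`: 6100 nM
compound 2 `Nc1ccccc1NC(=O)c1ccc(NC(=S)NCc2cccc(F)c2)cc1`: 2900 nM
compound 3 `Nc1ccccc1NC(=O)c1ccc(NC(=S)NCc2ccccc2F)cc1`: 5400 nM

In a functional assay on HepG2 cells (Homo sapiens) for cytotoxicity, read by MTT assay, with a stated time of 72 h (on this read-out higher numbers stand for weaker inhibition and lower numbers for stronger inhibition), compound 1 gives the highest number of the three. Its gap to compound 3 lies within the scatter, while its gap to compound 2 lies beyond it, so compound 1 gives a weaker result than compound 2 only.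

Going by the values given here, the only step between measured compounds is a 1.9-fold higher number from compound 2 to compound 3 (0.27 log units; within the scatter). It concerns the thiourea pair and not the bicyclic amide of compound 1, so it bears on the present question only as a sign that small moves within this set tend to stay within the scatter.

Compound 4 `Nc1ccccc1NC(=O)c1ccc(CNC(=O)c2ccc3cncn3c2)cc1` is the next compound. Relative to compound 1 the change is a group of 9 heavy atoms (7 carbon, 2 nitrogen; one five-membered aromatic ring with 2 hetero atoms, one six-membered aromatic ring with 1 hetero atom) in place of a group of 9 heavy atoms (7 carbon, 2 nitrogen; one five-membered aromatic ring with 1 hetero atom, one six-membered aromatic ring with 1 hetero atom), on a carbonyl carbon. Among the compounds with values here, no measured pair mirrors this exchange of one bicyclic amide for an isomeric one, so no step beyond the scatter is expected; compound 4 is estimated at 6000 nM, range 2500 nM to 15000 nM, in this assay. The expected step is a 1.0-fold lower number from compound 1 to compound 4 (0.01 log units; within the scatter).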

Compound 4, half-maximal inhibitory concentration: 3400 nM
Beside the measured number, compound 4's estimate is 1.8-fold (0.25 log units) above it, within the range that was stated.
By their numbers in this assay, from the lowest: compounds 2, 4, 3 and 1 (each within the scatter of the next, the first and the last beyond it).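

In this assay, the first exchange measured on this carbonyl carbon gives a 1.8-fold lower number from compound 1 to compound 4 (0.25 log units; within the scatter), so swapping one bicyclic group for its isomer does not move the result beyond the scatter. This exchange also takes the group from 1 hydrogen-bond donor to 0 and from 1 hydrogen-bond acceptor to 2, and the read-out tolerates that change in this single pair. No measured evidence on the compounds accounts for the result, so the data offer no explanation for it.

From the compounds shown here alone, whether a much smaller or non-bicyclic group on the same carbonyl carbon, such as a plain phenyl ring or a morpholine, would stay within the scatter of compound 1 remains open. Going by these compounds, it is also open whether this tolerance extends to other isomeric bicyclic groups, as one pair cannot establish a trend.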